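The source may hold more compounds than are shown below. What is called first, only, known or untested is meant among the compounds shown, and "the series" means these compounds.

Compound 1 `NC1=CS(=O)(=O)O[C@]12[C@@H](CO)O[C@@H](n1ccc(=O)[nH]c1=O)[C@@H]2O` is tested in a functional assay on MT4 cells (Homo sapiens) for cytotoxicity (on this read-out higher numbers stand for lower toxicity in this test and lower numbers for higher toxicity in this test), where compound 1 gives 320 ug/mL. Compound 3 `CC(C)(C)[Si](C)(C)O[C@H]1[C@H](n2ccc(=O)[nH]c2=O)O[C@H](CO)[C@]12OS(=O)(=O)C=C2N` carries a group of 7 heavy atoms (6 carbon, 1 silicon; no ring) in place of a hydrogen atom, on an oxygen on a saturated carbon, and in this assay compound 3 gives 221 ug/mL, a step of a 1.4-fold lower number from compound 1 to compound 3 (0.16 log units; within the scatter). Compound 2 `Cc1cn([C@@H]2O[C@H](CO)[C@@]3(OS(=O)(=O)C=C3N)[C@H]2O)c(=O)[nH]c1=O` is a different core; how it differs from the core of compound 1 is not broken down here. In this assay compound 2 reaches only a limit of the assay, > 100 ug/mL, and this is the limit of > 100 ug/mL in this assay, at which 1 of the 3 values shown sits. Compound 4 `Cc1cn([C@@H]2O[C@H](CO[Si](C)(C)C(C)(C)C)[C@@]3(OS(=O)(=O)C=C3N)[C@H]2O)c(=O)[nH]c1=O` carries a group of 7 heavy atoms (6 carbon, 1 silicon; no ring) in place of a hydrogen atom, on an oxygen on a saturated carbon, the same kind of change as in compound 3, though here the oxygen sits on a saturated chain carbon rather than a saturated ring carbon. From compound 2 to compound 4 a step that the limit leaves unreadable from compound 2 to compound 4 is expected, resting on the measured step of a 1.4-fold lower number from compound 1 to compound 3 (0.16 log units; within the scatter). Compound 4 is therefore estimated at 160 ug/mL, between 60 ug/mL and 400 ug/mL.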

Compound 4, half-maximal cytotoxic concentration: 45 ug/mL
For compound 4 the middle estimate is 3.6-fold (0.55 log units) above the measured one; the measured number lies below the stated range.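

In this assay, placing the group of 7 heavy atoms (6 carbon, 1 silicon) on an oxygen on a saturated carbon gives an at least 2.2-fold lower number from compound 2 to compound 4 (0.34 log units; beyond the scatter), while the same kind of change on the other core gives a 1.4-fold lower number from compound 1 to compound 3 (0.16 log units; within the scatter). Set side by side, these steps do not settle whether the change carries over with the same size: the same change on two cores in this assay, a 1.4-fold lower number (0.16 log units; within the scatter) from compound 1 to compound 3 and an at least 2.2-fold lower number (0.34 log units; beyond the scatter) from compound 2 to compound 4; the limit leaves it open whether they differ Nor do they separate the core from the place of the oxygen, which sits on a saturated chain carbon in compound 4 and on a saturated ring carbon in compound 3.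

The compounds shown leave open how a methyl ether or an acetyl ester on either oxygen would read in this test. They also leave open whether a longer chain on silicon would give a larger step.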